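This account rests on a few compounds, and the source may have more. Where it says the series, first, only, none or still open, it means among the compounds named here.

Measured so far:
compound 1 `CC(=O)O[C@@H](C[C@@H]1C(C)=CCC(=O)C1(C)C)/C(C)=C/[C@@H](C/C=C(\C)CC[C@H]1C(C)(C)[C@@H](O[C@@H]2O[C@H](CO)[C@H](O)[C@H](O)[C@H]2O)CC[C@]1(C)OC(C)=O)OC(C)=O`: 17000 nM
compound 2 `CC(=O)O[C@@H](C[C@@H]1C(C)=CCC(=O)C1(C)C)/C(C)=C/[C@@H](C/C=C(\C)CC[C@H]1C(C)(C)[C@@H](O)CC[C@]1(C)OC(C)=O)OC(C)=O`: 38900 nM
compound 3 `CC(=O)O[C@@H](C[C@H]1C(C)(C)C(=O)C=C[C@]1(C)O)/C(C)=C/[C@H](O)C/C=C(\C)CC[C@H]1C(C)(C)[C@@H](O[C@@H]2O[C@H](CO)[C@H](O)[C@H](O)[C@H]2O)CC[C@]1(C)OC(C)=O`: > 100000 nM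

In a functional assay on K562 cells (Homo sapiens) for cytotoxicity, read by spectrophotometry (a lower number here means a stronger inhibitor, a higher number a weaker inhibitor), compound 1 gives 17000 nM and compound 2 gives 38900 nM. For compound 3 this assay reports only a limit, > 100000 nM. The change from compound 1 to compound 2, (hydrogen in place of 3,4,5-trihydroxy-6-(hydroxymethyl)oxan-2-yl on an oxygen on a saturated carbon), makes a 2.3-fold higher number from compound 1 to compound 2 (0.36 log units; beyond the scatter).

Compound 4 `CC(=O)O[C@@H](C[C@H]1C(C)(C)C(=O)C=C[C@]1(C)O)/C(C)=C/[C@H](O)C/C=C(\C)CC[C@H]1C(C)(C)[C@@H](O)CC[C@]1(C)OC(C)=O` is not yet measured in this assay. It differs from compound 3 by hydrogen in place of 3,4,5-trihydroxy-6-(hydroxymethyl)oxan-2-yl on an oxygen on a saturated carbon, the same change at the same place as between compound 1 and compound 2. The difference between the core of compound 1 and the core of compound 3 is not broken down here.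

Compound 3 already sits at the limit of > 100000 nM in this assay, at which 1 of the 3 values shown sits. On the step seen from compound 1 to compound 2, a 2.3-fold higher number from compound 1 to compound 2 (0.36 log units; beyond the scatter), compound 4 is expected to give a higher number again, by about a step that the limit leaves unreadable from compound 3 to compound 4. Compound 4 is therefore estimated at 230000 nM, between 100000 nM and 600000 nM, and will most likely be reported only as a limit in this assay.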

Compound 4, half-maximal inhibitory concentration: 27500 nM
For compound 4 the middle estimate is 8.4-fold (0.92 log units) above the measured one, and the stated range ends above it.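

In this assay the same change, hydrogen in place of 3,4,5-trihydroxy-6-(hydroxymethyl)oxan-2-yl on an oxygen on a saturated carbon, gives an at least 3.6-fold lower number from compound 3 to compound 4 (0.56 log units; beyond the scatter), which runs opposite to the earlier step: the same change on two cores in this assay, a 2.3-fold higher number (0.36 log units; beyond the scatter) from compound 1 to compound 2 and an at least 3.6-fold lower number (0.56 log units; beyond the scatter) from compound 3 to compound 4, at least 8.3-fold (0.92 log units) apart, beyond the scatter of two such steps

Compound 3 is reported only as a limit, > 100000 nM.

The direction of this change therefore does not carry from one core to the other in these two pairs, but the size of the new step remains a minimum, and the data do not show which part of the difference between the core of compound 1 and the core of compound 3 goes with the reversal.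

Going by these compounds, with one pair on each of two cores, it remains open whether either direction would recur on a further core. Also open, on these data alone, is how this assay would read a methyl ether or an amine at this place, in place of the hydroxy or the 3,4,5-trihydroxy-6-(hydroxymethyl)oxan-2-yl group.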